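Methoxy for methyl at a cytotoxicity limit

A few compounds are considered here, and "the series" means these few. Any claim that something is new, unique, unknown or untested is made for them only; others in the source may bear on it.

Of the compounds shown here, three sharing one core have been tested in an ADME assay on L929 cells (Mus musculus) for cytotoxicity, read by resazurin assay, with a stated time of 72 h; a higher number here means a weaker inhibitor, a lower number a stronger inhibitor. Compound 1 `O=C(c1ccc(F)cc1)c1ccn(-c2ccc3c(c2)B(O)OC3)c1` carries a fluoro group on its outer aromatic ring. In this assay compound 1 gives only a limit, > 10 ug/mL. Compound 2 `Cc1ccc(C(=O)c2ccn(-c3ccc4c(c3)B(O)OC4)c2)cc1` carries a methyl group on that ring instead. In this assay compound 2 likewise gives only a limit, > 10 ug/mL. Compound 3 `Cc1ccccc1C(=O)c1ccn(-c2ccc3c(c2)B(O)OC3)c1` is the third member. In this assay compound 3 again gives only a limit, > 10 ug/mL. Because all three sit at the limit of > 10 ug/mL in this assay, at which 3 of the 3 values shown sit, none of the steps among them can be sized: the step that the two limits leave unreadable from compound 1 to compound 2, the step that the two limits leave unreadable from compound 1 to compound 3 and the step that the two limits leave unreadable from compound 2 to compound 3 are each unreadable. So compound 3 stands at the limit beside its two neighbours, with no number behind it.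

Compound 4 `COc1ccccc1C(=O)c1ccn(-c2ccc3c(c2)B(O)OC3)c1` is the next compound. Its change from compound 3 is methoxy in place of methyl on an aromatic carbon. Among the measured compounds shown here, no measured step bears directly on this change, and the three steps that exist give no readable size, so nothing argues for a move beyond the scatter in this assay. Compound 4 is therefore expected to remain at or near the limit, with an estimated step that the limit leaves unreadable from compound 3 to compound 4 that is effectively none. The estimate for compound 4 in this assay is 15 ug/mL, spanning 7 ug/mL to 40 ug/mL.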

Compound 4, half-maximal inhibitory concentration: > 10 ug/mL
Compound 4: a limit, no number; the forecaster's own chance of this, stated with the estimate: 80%; the middle value lies beyond the limit too.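

In this assay compound 4 gives > 10 ug/mL, which is a limit and not a number. The steps joining compound 4 to compound 1, compound 2 and compound 3 cannot be read, because all four compounds stop at the same point: the limit of > 10 ug/mL in this assay, at which 4 of the 4 values shown sit. The compounds shown leave open whether swapping methyl for methoxy changes cytotoxicity at all, and what any compound's actual value is.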